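Turning a Drawn Double Bond from Z to E

This account rests on a few compounds, and the source may have more. Where it says the series, first, only, none or still open, it means among the compounds named here.

Compound 1 `COc1ccc(C(O)(Cc2ccc(C)cc2)c2cccc3ccccc23)c(OC)c1OC` — in a functional assay on HCT-116 cells (Homo sapiens) for inhibition, read by sulforhodamine B assay, with a stated time of 48 h (on this read-out higher numbers stand for weaker inhibition and lower numbers for stronger inhibition), compound 1 gives > 20000 nM, which is a limit of the assay.
Compound 2 `COc1ccc(/C(=C\c2ccc(F)cc2)c2cccc3ccccc23)c(OC)c1OC` — in this assay compound 2 gives > 20000 nM, which is a limit of the assay.

For the measured compounds named here, both measured values sit at the limit of > 20000 nM in this assay, at which 2 of the 2 values shown sit, so compound 2 stands at the same limit as compound 1, and no measured step between two numbers exists in this set. Compound 3 `COc1ccc(/C(=C/c2ccc(F)cc2)c2cccc3ccccc23)c(OC)c1OC` differs from compound 2 only in the configuration drawn: the two compounds have the same atoms and bonds and differ only in configuration as drawn: 1 of 1 stereo elements differ; a double bond is drawn Z in compound 2 and E in compound 3, with no atom leaving or entering. Since neither measured compound yields a number, the size of a step cannot be read from the data; the account expects compound 3 to stay near the limit, with the step from compound 2 to compound 3 estimated as a number no higher from compound 2 to compound 3 (the limit leaves the size open), no larger than the scatter. Compound 3 is therefore estimated at 20000 nM, ranging from 4000 nM to 60000 nM.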

Compound 3, half-maximal inhibitory concentration: > 20000 nM
Compound 3 ended at the assay's limit (the forecaster's own chance of this, stated with the estimate: 60%); the middle value lies on the limit itself.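

In this assay compound 3 gives > 20000 nM, which is a limit of the assay. No step can be read between compound 2 and compound 3, so the change from Z to E has no readable size: the limit of > 20000 nM in this assay, at which 3 of the 3 values shown sit. The compounds shown leave open how the two drawn configurations would compare on an actual measured number.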